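Replacing a methoxyazetidine urea with an oxolane amide

A few compounds are considered here, and "the series" means these few. Any claim that something is new, unique, unknown or untested is made for them only; others in the source may bear on it.

Measured compounds:
compound 1, `CCn1c(-c2cnc(C)nc2)nc2c(N[C@H]3CCN(C(=O)C4CCC4)C3)ncnc21`, 0.6 h
compound 2, `CCC(=O)N1CC[C@H](Oc2ncnc3c2nc(-c2cnc(C)nc2)n3CC)C1`, 1.2 h
compound 3, `CCn1c(-c2ccc(C(F)(F)F)nc2)nc2c(O[C@H]3CCN(C(=O)N4CC(OC)C4)C3)ncnc21`, 2 h

Three compounds sharing one core have been examined in an ADME assay (Rattus norvegicus, strain Wistar Han) for metabolic stability; on this read-out higher numbers stand for a longer-lived compound and lower numbers for a shorter-lived compound. Compound 1 gives 0.6 h, compound 2 gives 1.2 h, and compound 3 gives 2 h. Of these three numbers, that of compound 3 is the largest, but its gap to compound 2 lies within the usual scatter of this assay, so the two cannot be ordered; only its gap to compound 1 lies beyond the scatter. No two of the measured compounds differ in a single place, so none of these gaps can be tied to one structural change.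

Compound 4, `CCn1c(-c2ccc(C(F)(F)F)nc2)nc2c(O[C@H]3CCN(C(=O)C4CCOC4)C3)ncnc21`, is not yet measured. It differs from compound 3 in one place: oxolan-3-yl in place of 3-methoxyazetidin-1-yl on a carbonyl carbon. Among the measured compounds shown here, the structures measured so far include no direct counterpart of this change, and the amide substituents of compound 1 and compound 2 sit on a different core from that of compound 3, so they offer no clean guide.

For the measured compounds named here, with no matching step to lean on, the step from compound 3 to compound 4 in this assay is expected to be small, a 1.3-fold lower number from compound 3 to compound 4 (0.12 log units; within the scatter), not beyond the scatter in either direction. Compound 4 is therefore estimated to give 1.5 h, within a range of 0.7 h to 3.5 h.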

Compound 4, half-life: 2.3 h
Beside the measured number, compound 4's estimate is 1.5-fold (0.19 log units) below it; measured number inside the range.
By their numbers in this assay, from the lowest: compounds 1, 2, 3 and 4 (each within the scatter of the next, the first and the last beyond it).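

In this assay, among the compounds shown here, putting oxolan-3-yl in place of 3-methoxyazetidin-1-yl on the carbonyl carbon gives a 1.2-fold higher number from compound 3 to compound 4 (0.06 log units; within the scatter), and this is the first comparison in the set that isolates a single place. The two compounds cannot be told apart on this read-out, so on this core the position holds either a urea bearing the four-membered ring or an amide bearing the five-membered ring without a readable difference, even though the atom joined to the carbonyl changes from a ring nitrogen to a ring carbon. No measurement shown here gives a reason for this outcome, and a step inside the scatter would in any case offer little to explain.

The compounds shown leave open whether the ring oxygen of the oxolan-3-yl group matters at all, a question that a cyclopentyl group on the same carbonyl carbon would address, and whether a morpholine or an open-chain methoxyethyl group would read the same way. For the compounds shown here, they also leave open whether this exchange would behave alike on the cores of compound 1 and compound 2, since no single-place pair connects those compounds to this one.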